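Spiro series on breast-cancer cells: ethoxy for methyl

The source may hold more compounds than are shown below. What is called first, only, known or untested is meant among the compounds shown, and "the series" means these compounds.

Two members of the series have been run in a functional assay on MCF7 cells (Homo sapiens) for antiproliferative activity, read by MTT assay, with a stated time of 48 h; on this read-out lower numbers stand for stronger inhibition and higher numbers for weaker inhibition. Compound 1 `N#CC1=C(N)Oc2c(c3nc4ccccc4nc3c3ccccc23)C12C(=O)N(Cc1cnnn1-c1ccc([N+](=O)[O-])cc1)c1ccccc12` carries a nitro-substituted aryl on the triazole; in this assay compound 1 returns only the limit > 50000 nM, not a number. Compound 2 `Cc1ccccc1-n1nncc1CN1C(=O)C2(C(C#N)=C(N)Oc3c(N)cc4nc5ccccc5nc4c32)c2ccccc21` carries a 2-methylphenyl on the triazole and an amine on the shared core; in this assay compound 2 likewise returns only the limit > 50000 nM. Compound 2 therefore stands where every value shown so far stands, namely at the limit of > 50000 nM in this assay, at which 2 of the 2 values shown sit. Among the measured compounds shown here, no step between measured compounds is available from which to gauge the change that follows.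

Compound 3 `CCOc1ccccc1-n1nncc1CN1C(=O)C2(C(C#N)=C(N)Oc3c(N)cc4nc5ccccc5nc4c32)c2ccccc21` differs from compound 2 in one place: ethoxy in place of methyl on an aromatic carbon Nothing measured in the series speaks to an ethoxy in this position. With both measured values sitting at the same limit, no direction can be read from the numbers. The step that the limit leaves unreadable from compound 2 to compound 3 is expected to stay within the scatter. Compound 3 is expected to return a limit rather than a number again. The estimate for compound 3 in this assay is 60000 nM, in the range 30000 nM to 150000 nM.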

Compound 3, half-maximal inhibitory concentration: > 50000 nM
Compound 3: a limit, no number; the forecaster's own chance of this, stated with the estimate: 85%; the middle value does not contradict the limit.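

In this assay compound 2 and compound 3 both return limits rather than numbers, so the step between them cannot be read and ethoxy in place of methyl has no readable size: the limit of > 50000 nM in this assay, at which 3 of the 3 values shown sit.

The compounds shown leave open whether any member of the series gives an actual number on this read-out, and whether 2-methylphenyl and 2-ethoxyphenyl differ at all.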